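Fluoro in Place of Hydrogen on the Aryl Ring of Compound 1

The source may report more compounds than this note shows. Statements on the series, on what has been measured and on what is new or still open speak of the compounds shown alone.

Compound 1 `COc1cc(N(CC(C)C)c2cccc(C(F)(F)F)c2)cnc1C(=O)[C@H]1C[C@@H]1C(=O)O` is one of three compounds tested in an ADME assay on cells (Hepatocyte, Homo sapiens) for metabolic stability, read by LC-MS, with a stated time of 60 min, tested at 1 uM; on this read-out lower numbers stand for slow clearance and higher numbers for fast clearance. In this assay compound 1 gives 2.9 uL/min. Compound 3 `COc1cc(N(Cc2ccc(F)cc2)c2cccc(C(F)(F)F)c2)cnc1C(=O)[C@H]1C[C@@H]1C(=O)O` gives 4.2 uL/min, and compound 2 `COc1cc(N(CC(C)(C)O)c2cccc(C(F)(F)F)c2)cnc1C(=O)[C@H]1C[C@@H]1C(=O)O` gives "not determined" (no result reported). The step of a 1.4-fold higher number from compound 1 to compound 3 (0.16 log units; within the scatter) is the only one measured, and it concerns a different site, so compound 1 and compound 3 sit within the scatter of each other and no direct guide exists for the change now considered. Compound 4 `COc1cc(N(CC(C)C)c2cc(C(F)(F)F)ccc2F)cnc1C(=O)[C@H]1C[C@@H]1C(=O)O` differs from compound 1 by fluoro in place of hydrogen on an aromatic carbon. Among the measured compounds shown here, with no measured step bearing on this change, the expected step of a 1.0-fold higher number from compound 1 to compound 4 (0.01 log units; within the scatter) is none beyond the scatter. Compound 4 is therefore estimated at 3 uL/min, within a range from 1.5 uL/min to 6 uL/min.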

Compound 4, intrinsic clearance in a liver preparation (reported as CLH), per the amount of preparation that the assay uses: 3.9 uL/min
Compound 4: the middle estimate sits 1.3-fold (0.11 log units) below what was measured, within the range that was stated.
By their numbers in this assay, from the lowest: compounds 1, 4 and 3 (each within the scatter of the next).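

The step of a 1.3-fold higher number from compound 1 to compound 4 (0.13 log units; within the scatter) shows that in this assay this aromatic carbon, ortho to a large group and para to a trifluoromethyl group, accepts a fluoro with no change beyond the scatter. Nothing measured here explains this result.

Still open, going by these compounds, is how a chlorine, a methoxy group or a nitrile would behave on this same carbon. On these data alone, it is also open whether fluoro on another carbon of this ring would stay within the scatter too.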